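Swapping nitro for chloro on a shared triazole core

The compounds below may be only part of what the source reports. "The series", "measured", "known", "first", "only" and "open" are said of these compounds alone.

Compounds measured so far in a functional assay on HeLa cells (Homo sapiens) for inhibition, read by MTT assay, with a stated time of 48 h; on this read-out lower numbers stand for stronger inhibition and higher numbers for weaker inhibition:
compound 1, `CS(=O)(=O)Nc1ccc(-n2cc(COc3ccc([N+](=O)[O-])cc3)nn2)cc1Oc1ccccc1`: "not determined" (no result reported)
compound 2, `CS(=O)(=O)Nc1ccc(-n2cc(OCc3ccccc3)nn2)cc1Oc1ccccc1`: "not determined" (no result reported)
compound 3, `CS(=O)(=O)Nc1ccc(-n2cc(COc3ccc4ccccc4c3)nn2)cc1Oc1ccccc1`: 12800 nM

Compound 1 has no number in this assay, and compound 2 is in the same position, so the only anchor in this series is compound 3, which in this assay gives 12800 nM. Compound 1 therefore stands nowhere on the numbers shown; its place can only be inferred from its neighbour compound 3, which shares the whole core and differs only in the aryl group hung from the phenoxymethyl arm.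

The step under consideration leads from compound 1 to compound 4, `CS(=O)(=O)Nc1ccc(-n2cc(COc3ccc(Cl)cc3)nn2)cc1Oc1ccccc1`. The change is chloro in place of nitro on an aromatic carbon, sitting on an aromatic carbon of a six-membered aromatic ring of carbon only. Going by the values given here, no step between two measured compounds is available to calibrate it. With compound 3 as the sole reference, the expected size of the step in this assay is modest, likely within the scatter, with no clear direction.

Compound 4 is expected to give about 15000 nM in this assay, with a plausible range from 4000 nM to 60000 nM.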

Compound 4, half-maximal inhibitory concentration: 7800 nM
For compound 4 the middle estimate is 1.9-fold (0.28 log units) above the measured one, and the stated range covers the measured number.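

In this assay, the arm on the shared core now carries a second aryl group with a number, and replacing naphthalen-2-yl with 4-chlorophenyl gives a 1.6-fold lower number from compound 3 to compound 4 (0.22 log units; within the scatter); on these two compounds, the large fused aryl group and the smaller chlorinated one cannot be told apart. Compound 1 has no single number, however, and the step from nitro to chloro cannot be read, so the change at this position still has neither a size nor a direction. No measured evidence bears on this result.

The compounds shown leave open what nitro itself would read on this arm, and whether any group on this aromatic carbon moves the number beyond the scatter. They also do not show whether an amine or a carboxylic acid in place of chloro, on the same aromatic carbon, would separate from the 4-chlorophenyl and naphthalen-2-yl compounds in this assay.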